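Swapping a Furan for a Chloropyridine: an Estimate

This account rests on a few compounds, and the source may have more. Where it says the series, first, only, none or still open, it means among the compounds named here.

Measured compounds:
- compound 1, `Nc1nc(-c2ccc(Cl)cc2)c(CC(=O)O)s1`: > 100000 nM
- compound 2, `O=C(O)Cc1sc(C(c2ccc(F)cc2)c2ccc(F)cc2)nc1-c1ccco1`: 18 nM
- compound 3, `O=C(O)Cc1sc(C(c2ccccc2)c2ccccc2)nc1-c1ccc(F)c(F)c1`: 4.1 nM

All three compounds were tested in an in vitro assay on HEK385-7 cells for displacement of a labelled ligand from prostaglandin D2 receptor 2 (Homo sapiens); on this read-out lower numbers stand for stronger inhibition and higher numbers for weaker inhibition. Compound 1 gives only a limit there, > 100000 nM, which means no number could be read; (the limit of > 100000 nM in this assay, at which 1 of the 3 values shown sits). Among the two numbers that were read, compound 2 stands highest with 18 nM, while compound 3 sits at 4.1 nM, a gap that lies beyond the usual scatter. No pair of these compounds differs in a single place, so no step between them can be drawn.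

The unmeasured compound 4, `O=C(O)Cc1sc(C(c2ccc(F)cc2)c2ccc(F)cc2)nc1-c1ccnc(Cl)c1`, differs from compound 2 in one place: 2-chloropyridin-4-yl in place of furan-2-yl on an aromatic carbon. Compound 3 shows that a six-membered aromatic ring in this position is compatible with a low number, and the rest of compound 4 is the same as in compound 2, so compound 2 at 18 nM is the anchor. The step from compound 2 to compound 4 in this assay is expected to be small, most likely a modest drop rather than a rise, a 1.8-fold lower number from compound 2 to compound 4 (0.26 log units; within the scatter). For compound 4 the estimated value is 10 nM, with a range from 2.5 nM to 45 nM.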

Compound 4, half-maximal inhibitory concentration: 3.1 nM
Estimate against measurement, compound 4: 3.2-fold (0.51 log units) above, and the stated range covers the measured number.
By their numbers in this assay, from the lowest: compounds 4 and 3 (each within the scatter of the next); then compound 2. At a limit, above all of these: compound 1.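

In this assay, among the compounds shown here, replacing furan-2-yl with 2-chloropyridin-4-yl while the rest of the molecule stays the same gives a 5.8-fold lower number from compound 2 to compound 4 (0.76 log units; beyond the scatter), and this is the first change in the set that can be read at a single place. It shows that this aromatic carbon, next to the ring nitrogen, accepts a six-membered aromatic ring bearing a chlorine in place of a five-membered one, and that the number falls rather than rises, even though the two groups have the same counts of hydrogen-bond donors and acceptors and neither has a net charge. Nothing measured here tells which part of the swap, whether the ring size, the ring nitrogen or the chlorine, accounts for the step.

These three features change together, so the compounds shown leave open what the chlorine contributes, a question that a plain pyridin-4-yl group, or a pyridine with a methyl group or an amine in the chlorine's place, would help to answer. Also open, going by these compounds, is whether a longer chain in place of the carboxymethyl group would keep the low number alongside the new ring.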